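Changing the amide ring in a kinase inhibitor pair

This account rests on a few compounds, and the source may have more. Where it says the series, first, only, none or still open, it means among the compounds named here.

Measured so far:
compound 1 `Cc1cc(C(=O)Nc2cccc(NC(=O)COc3ccc4c(=O)ccoc4c3)c2)ccc1C(F)(F)F`: 43 nM
compound 2 `O=C(COc1ccc2c(=O)ccoc2c1)Nc1cccc(NC(=O)c2cnc(C(F)(F)F)s2)c1`: 10 nM

In an assay on isolated protein for inhibition of Rho-associated protein kinase 2 (Homo sapiens), read by scintillation counting, radiometric assay and 33P incorporation, with a stated time of 40 min, in the presence of a further agent that is not named here (on this read-out lower numbers stand for stronger inhibition and higher numbers for weaker inhibition), compound 1 gives 43 nM, while compound 2 gives 10 nM, the lowest number of the two. Going by the values given here, the only measured step, a 4.3-fold lower number from compound 1 to compound 2 (0.63 log units; beyond the scatter), shows that exchanging the ring on the carbonyl carbon can move the number noticeably. Compound 3 `Cc1cc(C(=O)Nc2cccc(NC(=O)COc3ccc4c(=O)ccoc4c3)c2)no1` differs from compound 2 by 5-methyl-1,2-oxazol-3-yl in place of 2-(trifluoromethyl)-1,3-thiazol-5-yl on a carbonyl carbon. That single step bears on this change but involved a different ring, so its direction cannot be carried over with confidence. Compound 3 is therefore expected to show a modest rise, a 2.5-fold higher number from compound 2 to compound 3 (0.40 log units; beyond the scatter), landing at an estimated 25 nM (range 6 nM to 100 nM).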

Compound 3, half-maximal inhibitory concentration: 5 nM
Compound 3: middle estimate off by 5.0-fold (0.70 log units), on the high side, and the stated range ends above it.
By their numbers in this assay, from the lowest: compounds 3 and 2 (each within the scatter of the next); then compound 1.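

With a 2.0-fold lower number from compound 2 to compound 3 (0.30 log units; within the scatter), 5-methyl-1,2-oxazol-3-yl on the carbonyl carbon does as well as 2-(trifluoromethyl)-1,3-thiazol-5-yl, despite having fewer heavy atoms and no fluorine, so trifluoromethyl is not required at this position. A second five-membered ring also compares well with the six-membered carbon-only ring, giving an 8.6-fold lower number from compound 1 to compound 3 (0.93 log units; beyond the scatter). Nothing measured here explains either result. Still open, from the compounds shown here alone, is whether the methyl group on the 1,2-oxazole ring matters, and how a pyridine ring or an amine on the carbonyl carbon would compare.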